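A few compounds are considered here, and "the series" means these few. Any claim that something is new, unique, unknown or untested is made for them only; others in the source may bear on it.

In an assay on CHO cells for displacement of a labelled ligand from prostaglandin E2 receptor EP3 subtype (Homo sapiens), read by radioligand binding (a higher number here means a weaker inhibitor, a lower number a stronger inhibitor), three compounds sharing one core have been measured. Compound 1 `CC(C)C(Nc1nnc[nH]1)c1ccc(-c2ccc3cccc(F)c3c2)[nH]c1=O` gives 22 nM in this assay, compound 2 `CC(C)C(c1ncco1)c1ccc(-c2ccc3cccc(F)c3c2)[nH]c1=O` gives 24 nM, and compound 3 `CC(C)C(c1nnc[nH]1)c1ccc(-c2ccc3cccc(F)c3c2)[nH]c1=O` gives 12 nM. Compound 3 carries the lowest of the three numbers, but the step of a 1.8-fold lower number from compound 1 to compound 3 (0.26 log units; within the scatter) and the step of a 2.0-fold lower number from compound 2 to compound 3 (0.30 log units; within the scatter) both stay within the scatter, so the three compounds cannot be told apart on these data.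

Compound 4 `CC(C)C(Cc1noc(=O)[nH]1)c1ccc(-c2ccc3cccc(F)c3c2)[nH]c1=O` changes the same position once more: a group of 7 heavy atoms (3 carbon, 2 nitrogen, 2 oxygen; one five-membered aromatic ring with 3 hetero atoms) in place of a group of 5 heavy atoms (2 carbon, 3 nitrogen; one five-membered aromatic ring with 3 hetero atoms), on a saturated chain carbon bound to an aromatic carbon and a saturated chain carbon. The measured steps that touch this position are a 1.1-fold higher number from compound 1 to compound 2 (0.04 log units; within the scatter), a 1.8-fold lower number from compound 1 to compound 3 (0.26 log units; within the scatter) and a 2.0-fold lower number from compound 2 to compound 3 (0.30 log units; within the scatter); each of them stayed within the scatter, although the group at this position was changed widely among them. Within the data shown here, nothing measured shows that any group at this position moves the number beyond the scatter, and the new group has no measured precedent here. The expected step of a 2.1-fold higher number from compound 3 to compound 4 (0.32 log units; beyond the scatter) is therefore taken as small, with some allowance for a weaker number because compound 3 already holds the lowest value, 12 nM, of the set. The estimate for compound 4 in this assay is 25 nM, expected to fall between 8 nM and 80 nM.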

Compound 4, inhibition constant: 34 nM
The estimate for compound 4 lay 1.4-fold (0.13 log units) below the measured number, within the range that was stated.
By their numbers in this assay, from the lowest: compounds 3, 1, 2 and 4 (each within the scatter of the next, the first and the last beyond it).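

In this assay this position, on a saturated chain carbon bound to an aromatic carbon and a saturated chain carbon, now gives its first step beyond the scatter (a 2.8-fold higher number from compound 3 to compound 4 (0.45 log units; beyond the scatter)), a modest one, when the group of 7 heavy atoms takes the place of 4H-1,2,4-triazol-3-yl. The same group stays within the scatter of the other two groups (a 1.4-fold higher number from compound 2 to compound 4 (0.15 log units; within the scatter)) and (a 1.5-fold higher number from compound 1 to compound 4 (0.19 log units; within the scatter)), so it is set apart only from 4H-1,2,4-triazol-3-yl, not from 1,3-oxazol-2-yl or (4H-1,2,4-triazol-3-yl)amino. A larger group with a double bond outside its ring is thus accepted here at the cost of a modest step at most, and nothing available explains that step.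

As far as these compounds go, whether a group without a ring at this place, such as a carboxylic acid or a simple amine, would keep the number in this range remains open. Also open, from the compounds shown here alone, is whether the ring of the entering group or the atoms outside that ring account for the step from 4H-1,2,4-triazol-3-yl.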